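Pentan-3-yl ester after isobutyl and cyclohexyl esters

The source may hold more compounds than are shown below. What is called first, only, known or untested is meant among the compounds shown, and "the series" means these compounds.

Of the compounds shown here, two have been measured in an ADME assay on microsomes from liver (Mus musculus) for metabolic stability, with a stated time of 30 min; a lower number here means that less of the compound is left, a higher number that more of the compound is left. Compound 1 `CCCCc1nc(C(C)C)c(CC(=O)OCC(C)C)c(=O)n1Cc1ccc(-c2ccccc2-c2noc(=O)[nH]2)cc1` gives 13.7% in this assay, and compound 2 `CCCCc1nc(C(C)C)c(CC(=O)OC2CCCCC2)c(=O)n1Cc1ccc(-c2ccccc2-c2noc(=O)[nH]2)cc1` gives 14.6%. The step of a number 0.9 percentage points higher from compound 1 to compound 2 (within the scatter) lies within the scatter, so compound 2 stands together with compound 1 rather than apart from it, and the two numbers cannot be told apart. Compound 3 `CCCCc1nc(C(C)C)c(CC(=O)OC(CC)CC)c(=O)n1Cc1ccc(-c2ccccc2-c2noc(=O)[nH]2)cc1` differs from compound 2 by pentan-3-yl in place of cyclohexyl on an oxygen next to a carbonyl group. Among the measured compounds shown here, the one measured step that bears on this position, from compound 1 to compound 2, exchanged one group on the oxygen next to the carbonyl group for another without a change beyond the scatter. On that basis the expected step is a number 0.6 percentage points lower from compound 2 to compound 3 (within the scatter), which is no more than the scatter. Compound 3 is therefore estimated to give about 14% in this assay, with a range from 6% to 25%.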

Compound 3, percent of the compound remaining: 14.6%
The estimate for compound 3 lay 0.6 percentage points below the measured number; the range from low to high includes it.
By their numbers in this assay, from the lowest: compounds 1, 2 and 3 (each within the scatter of the next).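

In this assay, removing the ring from this group, with pentan-3-yl in place of cyclohexyl on the oxygen next to the carbonyl group, gives no change at the digits printed from compound 2 to compound 3 (within the scatter) for the first ring-to-open-chain exchange shown here. The exchange between the two open groups reads a number 0.9 percentage points higher from compound 1 to compound 3 (within the scatter), so isobutyl, cyclohexyl and pentan-3-yl all stand together within the scatter, and neither the ring nor the change from isobutyl to pentan-3-yl separates these compounds in this read-out. Nothing available explains why these three numbers cannot be told apart.

Still open, going by these compounds, is whether a group carrying an amine on this oxygen, or a longer straight chain such as octyl, would move the number beyond the scatter. Also open, on these data alone, is what a free carboxylic acid in place of the ester would give in this assay on the same core.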